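Extending the ethoxy group of compound 3

The source may report more compounds than this note shows. Statements on the series, on what has been measured and on what is new or still open speak of the compounds shown alone.

Of the compounds shown here, three have been measured in a toxicity assay on Huh-7.5 cells (Homo sapiens) for inhibition, read by MTT assay, with a stated time of 96 h; on this read-out lower numbers stand for higher toxicity in this test and higher numbers for lower toxicity in this test. Compound 1 `CCC(=O)Nc1cc(C(=O)Nc2ccc(OC)cc2)ccc1OC` gives 109000 nM, and compound 3 `CCOc1ccc(C(=O)Nc2ccc(OC)cc2)cc1NC(=O)CC` gives 73200 nM, so these two stand level within the scatter. Compound 2 `CN1CCN(Cc2ccc(NC(=O)c3ccc(OCCCCl)c([N+](=O)[O-])c3)cc2C#N)CC1`, which differs from them in more than one place, gives a lower number, 15500 nM.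

Compound 4 `CCC(=O)Nc1cc(C(=O)Nc2ccc(OC)cc2)ccc1OCCCN1CCN(C)CC1` differs from compound 3 as follows: (4-methylpiperazin-1-yl)methyl in place of hydrogen on a saturated chain carbon, two bonds along the chain from an oxygen on an aromatic ring. The same difference reads ethoxy to 3-(4-methylpiperazin-1-yl)propoxy. Within the data shown here, the only measured step, a 1.5-fold lower number from compound 1 to compound 3 (0.17 log units; within the scatter), added just a methyl in place of hydrogen, so it says little about a group of this size. Among the measured compounds shown here, the sole other hint is compound 2, which also carries a (4-methylpiperazin-1-yl)methyl group and gives 15500 nM, although it is a single compound with a different structure. A moderate move towards lower numbers in this assay is therefore expected, an estimated 2.3-fold lower number from compound 3 to compound 4 (0.36 log units; beyond the scatter). For compound 4 the estimated value is 32000 nM, with an expected range from 11000 nM to 90000 nM.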

Compound 4, half-maximal cytotoxic concentration: 127000 nM
Compound 4: the middle estimate sits 4.0-fold (0.60 log units) below what was measured; the measured number lies above the stated range.
By their numbers in this assay, from the lowest: compound 2; then compounds 3, 1 and 4 (each within the scatter of the next).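

In this assay, the position two bonds along the chain from an oxygen on an aromatic ring takes (4-methylpiperazin-1-yl)methyl, a group with one six-membered non-aromatic ring, with a 1.7-fold higher number from compound 3 to compound 4 (0.24 log units; within the scatter). Measured against the methoxy compound, the whole 2-(4-methylpiperazin-1-yl)ethyl extension gives a 1.2-fold higher number from compound 1 to compound 4 (0.07 log units; within the scatter), so across these three compounds, neither a methyl nor this much larger group moves the number beyond the scatter. No available evidence accounts for this result.

Going by these compounds, it remains open whether a carboxylic acid or a primary amine in place of the (4-methylpiperazin-1-yl)methyl group, or a longer chain carrying the same ring, would also stay within the scatter. Compound 2 differs from these compounds in more than one place, so its lower number cannot be tied to any single part of its structure.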